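Swapping the Aryl Amide: Chlorine Out, Fluorine In

This account rests on a few compounds, and the source may have more. Where it says the series, first, only, none or still open, it means among the compounds named here.

Three amides built on one shared core have been measured in an assay on MDA-MB-231 cells for binding affinity to C-X-C chemokine receptor type 4 (Homo sapiens), read by immunofluorescence and microscopy, with stated times of 10 min and 30 min; a lower number here means that less compound is needed, a higher number that more compound is needed for the effect. Compound 1, `O=C(NCc1ccc(CNS(=O)(=O)c2ccccc2)cc1)c1ccncc1`, gives 10 nM. Compound 2, `O=C(NCc1ccc(CNS(=O)(=O)c2ccccc2)cc1)c1c(Cl)cc(Cl)cc1Cl`, gives 10 nM, and the change no change at the digits printed from compound 1 to compound 2 (within the scatter) stays within the scatter. Compound 3, `O=C(NCc1ccc(CNS(=O)(=O)c2ccccc2)cc1)c1ccc(Cl)cc1`, gives 100 nM, the highest number of the three: the steps of a 10-fold higher number from compound 1 to compound 3 (1.00 log units; beyond the scatter) and a 10-fold higher number from compound 2 to compound 3 (1.00 log units; beyond the scatter) both go beyond the scatter, so compound 3 needs clearly more material than either of its neighbours.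

Compound 4, `O=C(NCc1ccc(CNS(=O)(=O)c2ccccc2)cc1)c1ccccc1F`, differs from compound 3 in one place: 2-fluorophenyl in place of 4-chlorophenyl on a carbonyl carbon. Cut one bond further out, the (4-chlorophenyl)carbonyl becomes a (2-fluorophenyl)carbonyl.

The two steps that bear on this change are the ones that reach compound 3, since each alters the group on the carbonyl carbon, and each was modest in size. Within the data shown here, no measured step brings in a 2-fluorophenyl, so the direction of the new step is not fixed by the data. Because compound 3 gives 100 nM with the 4-chlorophenyl while both other aryl groups sit lower, moving away from that group is expected more likely to lower the number than to raise it. Compound 4 is therefore expected to give about 30 nM, within 5 nM to 200 nM. The estimated step of a 3.3-fold lower number from compound 3 to compound 4 (0.52 log units; beyond the scatter) is a moderate lowering, with a result inside the scatter also possible.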

Compound 4, effective concentration (reported as EC, without a stated level of effect): 1000 nM
The estimate for compound 4 lay 33-fold (1.52 log units) below the measured number, and the stated range ends below it.
By their numbers in this assay, from the lowest: compounds 1 and 2 (each within the scatter of the next); then compound 3; then compound 4.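

The 4-chlorophenyl group does not mark the top of the range at this position on the carbonyl carbon: in this assay the number climbs again, with a 10-fold higher number from compound 3 to compound 4 (1.00 log units; beyond the scatter). Measured against the two lowest compounds, the same swap gives a 100-fold higher number from compound 2 to compound 4 (2.00 log units; beyond the scatter) and a 100-fold higher number from compound 1 to compound 4 (2.00 log units; beyond the scatter), so changing this one group on the shared core is enough to span the whole spread seen so far, and halogen-bearing phenyl groups sit at both ends of it, with 2,4,6-trichlorophenyl at the low end and 2-fluorophenyl at the high end. Nothing available bears on the reason for these differences.

The change from 4-chlorophenyl to 2-fluorophenyl alters both the halogen and the number in the group's name, so these compounds cannot show how much of the rise goes with each. As far as these compounds go, how a plain phenyl group on the carbonyl carbon would compare also stays open, as does the effect of an amine or a carboxylic acid on that ring.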